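Methoxyphenyl Swap Expected to Leave Inhibition Near Baseline

The source may report more compounds than this note shows. Statements on the series, on what has been measured and on what is new or still open speak of the compounds shown alone.

Compound 3 `CC(C)(C)Cc1c(-c2ccc(Cl)c(Cl)c2)sc(N)c1C(=O)c1ccc(Cl)cc1` gives 1% in an assay on CHO cells for displacement of a labelled ligand from adenosine receptor A3 (Homo sapiens), read by scintillation counting, tested at 10 uM; on this read-out lower numbers stand for less inhibition and higher numbers for more inhibition at the one concentration tested (going by the name of the read-out). Compound 1 `CC(C)(C)Cc1csc(N)c1C(=O)c1ccc(Cl)cc1` gives 5% and compound 2 `CC(C)(C)Cc1c(-c2ccc(F)cc2F)sc(N)c1C(=O)c1ccc(Cl)cc1` gives 1%, so compound 3 sits level with compound 2, the two together forming the lowest pair of the three. Compound 4 `COc1ccccc1-c1sc(N)c(C(=O)c2ccc(Cl)cc2)c1CC(C)(C)C` differs from compound 3 by 2-methoxyphenyl in place of 3,4-dichlorophenyl on an aromatic carbon. Going by the values given here, the steps that bear on this change are a number 4 percentage points lower from compound 1 to compound 2 (within the scatter), a number 4 percentage points lower from compound 1 to compound 3 (within the scatter) and no change at the digits printed from compound 2 to compound 3 (within the scatter), each within the scatter. Neither attaching an aryl group at this carbon nor exchanging one aryl group for another has moved the read-out beyond the scatter, so the step of a number 2 percentage points higher from compound 3 to compound 4 (within the scatter) is expected to be none beyond the scatter. Compound 4 is therefore estimated at 3%, with a range from 0% to 12%.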

Compound 4, a percentage reported as inhibition, at one concentration (the size of the read-out at that concentration, not a potency): 1%
Beside the measured number, compound 4's estimate is 2 percentage points above it; the measured number falls inside the stated range.
By their numbers in this assay, from the lowest: compounds 2, 3, 4 and 1 (each within the scatter of the next).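

In this assay, 2-methoxyphenyl, which carries no halogen and has 1 hydrogen-bond acceptor, reads like the halogenated aryl groups at this carbon: no change at the digits printed from compound 3 to compound 4 (within the scatter) and no change at the digits printed from compound 2 to compound 4 (within the scatter) are the steps. Set against hydrogen, the same swap gives a number 4 percentage points lower from compound 1 to compound 4 (within the scatter) and so extends the flat picture to a third aryl group. No evidence here explains this flatness.

As far as these compounds go, what an amine or a carboxylic acid at this carbon would do remains open. So does the effect of replacing the aryl group with a longer chain.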